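Swapping a hydroxycyclohexyl group for a butyl chain

A few compounds are considered here, and "the series" means these few. Any claim that something is new, unique, unknown or untested is made for them only; others in the source may bear on it.

Of the compounds shown here, three with a shared core have been measured in an assay on isolated protein for binding affinity to adenosine receptor A1 (Bos taurus); on this read-out lower numbers stand for stronger inhibition and higher numbers for weaker inhibition. Compound 1 `CNc1nc(-c2ccccc2)nc2c1nnn2Cc1ccccc1Cl` gives 191000000 nM in this assay. Compound 3 `CCNc1nc(-c2ccccc2)nc2c1nnn2Cc1ccccc1Cl` gives 463000000 nM, and the step of a 2.4-fold higher number from compound 1 to compound 3 (0.38 log units; beyond the scatter) is a modest one. Among the compounds with values here, compound 2 `OC1CCC(Nc2nc(-c3ccccc3)nc3c2nnn3Cc2ccccc2F)CC1` carries a 4-hydroxycyclohexyl group in place of the small alkyl groups of compounds 1 and 3 and a fluorine instead of chlorine on its benzyl ring; in this assay compound 2 gives 1850000 nM, the lowest of the three numbers, and no single-change step links it to compound 1 or compound 3.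

Compound 4 `CCCCNc1nc(-c2ccccc2)nc2c1nnn2Cc1ccccc1F` keeps the fluorinated benzyl group of compound 2 and differs from it only by butyl in place of 4-hydroxycyclohexyl on a nitrogen on an aromatic ring. Within the data shown here, the one measured step that bears on this change, from compound 1 to compound 3, shows that lengthening the alkyl chain on that nitrogen raises the number by a 2.4-fold higher number from compound 1 to compound 3 (0.38 log units; beyond the scatter). Since compound 2 with its hydroxycyclohexyl group gives 1850000 nM while compounds 1 and 3 with plain alkyl groups give far higher numbers, the step from compound 2 to compound 4 is expected to raise the number substantially. Compound 4 is therefore estimated at 80000000 nM, with a range of 5000000 nM to 800000000 nM, which corresponds to an expected step of a 43-fold higher number from compound 2 to compound 4 (1.64 log units; beyond the scatter).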

Compound 4, inhibition constant: 4300000 nM
Beside the measured number, compound 4's estimate is 19-fold (1.27 log units) above it; measured number outside the range, below it.
By their numbers in this assay, from the lowest: compound 2; then compound 4; then compound 1; then compound 3.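

In this assay, exchanging 4-hydroxycyclohexyl for butyl on a nitrogen on an aromatic ring, with the fluorinated benzyl group held fixed, gives a 2.3-fold higher number from compound 2 to compound 4 (0.37 log units; beyond the scatter). Within the data shown here, this is the first single-change reading at this position of a ring group against an open chain, and it shows that the position tolerates losing the six-membered ring, together with its hydrogen-bond donor and hydrogen-bond acceptor, with only a modest change in the number, though one that lies beyond the usual scatter. No measurement presented here accounts for the size or direction of this step.

As far as these compounds go, what a plain cyclohexyl group on that nitrogen would give remains open, and with it the question of whether the step follows the ring, the hydroxyl group or the change in chain shape. The effect of the halogen on the benzyl ring also remains unresolved, as no two compounds shown differ in that place alone, so the fluorinated compounds cannot yet be set directly against the chlorinated ones.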